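This account rests on a few compounds, and the source may have more. Where it says the series, first, only, none or still open, it means among the compounds named here.

Measured so far in an ADME assay on Vero cells (Chlorocebus sabaeus) for cytotoxicity, read by luminescence, with a stated time of 2 days; a higher number here means that more compound is tolerated, a lower number that less compound is tolerated:
- compound 1 `CCc1nc2ccc(OC)cc2n1CCCCOc1ccccc1`: 27 uM
- compound 2 `CCc1nc2cc(OC)ccc2n1CCCCOc1ccccc1`: "not determined" (no result reported)
- compound 3 `CCc1nc2ccc(C#N)cc2n1CCCCOc1ccccc1`: > 20 uM

Compound 3 sits at a limit of this assay rather than at a number, and this is the line the limit of > 20 uM in this assay, at which 1 of the 3 values shown sits, at which one of the three values shown sits. Compound 1 and compound 2 share the same atoms joined differently; the difference between the two cores is not broken down here. Compound 4 `CCc1nc2cc(C#N)ccc2n1CCCCOc1ccccc1` is not yet measured. Going by the values given here, the change from compound 2 to compound 4 is cyano in place of methoxy on an aromatic carbon, and the same change, at the same place, is the one from compound 1 to compound 3, (cyano in place of methoxy on an aromatic carbon). Its step in this assay, a step that the limit leaves unreadable from compound 1 to compound 3, cannot be read in size because compound 3 stands at the limit (the limit of > 20 uM in this assay, at which 1 of the 3 values shown sits). For compound 2 nothing is known in this assay, so the expectation for compound 4 rests on compound 1 and its value 27 uM and on the fact that the step to compound 3 did not fall visibly below it. Compound 4 is expected to tolerate roughly 25 uM, with a range from 10 uM to 60 uM estimated, and a limit rather than a number may again be reported.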

Compound 4, half-maximal toxic concentration: > 20 uM
Compound 4: no number, only a limit; the forecaster's own chance of this, stated with the estimate: 50%; the middle value does not contradict the limit.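

In this assay compound 4 gives > 20 uM, which is a limit and not a number, and compound 2 has no number to compare with it, so no new step can be read between the two. The compounds shown leave open how compound 3 and compound 4 stand relative to each other and to compound 1.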